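The source may hold more compounds than are shown below. What is called first, only, known or untested is meant among the compounds shown, and "the series" means these compounds.

Three compounds sharing one core have been run in an assay for inhibition of Indoleamine 2,3-dioxygenase 1 (Homo sapiens), read by spectrophotometry, with a stated time of 180 min, tested at 10 uM; a higher number here means a stronger effect of the compound at the concentration tested, a lower number a weaker effect. Compound 1 `O=C(O)c1ccc(CNc2cc(Br)cc3[nH]ncc23)cc1` gives 49%. Compound 2 `O=C(O)c1cccc(CNc2cc(Br)cc3[nH]ncc23)c1` gives 21%. Compound 3 `O=C(O)c1cc(CNc2cc(Br)cc3[nH]ncc23)ccc1O` gives 38%, the second highest of the three numbers: compound 1 stands higher and compound 2 lower, both gaps beyond the scatter. Among the measured compounds shown here, the only step between measured compounds that differ in one place, a number 17 percentage points higher from compound 2 to compound 3 (beyond the scatter), is a modest gain beyond the scatter.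

Compound 4 `Oc1ccc(CNc2cc(Br)cc3[nH]ncc23)cc1` has not yet been measured in this assay. From compound 3 it differs by hydrogen in place of carboxy on an aromatic carbon. For the measured compounds named here, no measured step removes the carboxy from this core; the step from compound 2 to compound 3 concerns the hydroxy only, and compound 1 at 49% against compound 2 at 21% shows merely that where the carboxy sits matters. Loss of the carboxy is therefore expected to cost inhibition, probably beyond the scatter, though the size is uncertain. Compound 4 is estimated at 22%, within 5% to 42%, a step of a number 16 percentage points lower from compound 3 to compound 4 (beyond the scatter).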

Compound 4, a percentage reported as inhibition, at one concentration (the size of the read-out at that concentration, not a potency): 70%
The estimate for compound 4 lay 48 percentage points below the measured number; the whole stated range lies below it.
By their numbers in this assay, from the lowest: compound 2; then compound 3; then compound 1; then compound 4.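

Taking the carboxy away from its place ortho to a hydroxy group gives a number 32 percentage points higher from compound 3 to compound 4 (beyond the scatter) in this assay, so on this core a carboxy on the aromatic ring is not needed for inhibition, and its removal here raises the number instead of lowering it. Hydroxy in place of carboxy gives a number 21 percentage points higher from compound 1 to compound 4 (beyond the scatter) and so shows the same direction for a second compound that carries a carboxy, without a hydroxy group on its ring. Nothing at hand bears on why the number rises when the carboxy goes.

Open, on these data alone, is what the hydroxy of compound 4 adds on its own compared with plain hydrogen on that carbon. Also open, as far as these compounds go, is whether a methoxy or an amine there would hold or pass the number of compound 4.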